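A few compounds are considered here, and "the series" means these few. Any claim that something is new, unique, unknown or untested is made for them only; others in the source may bear on it.

Measured compounds:
compound 1, `C/N=C(\S)NCCCCCn1nc(-c2ccccc2)ccc1=O`, 68.9% in a functional assay on the whole organism with Rattus norvegicus as the target, at a dose of 100 mg/kg; a lower number here means less inhibition, a higher number more inhibition at the dose given (going by the name of the read-out)
compound 2, `CC/N=C(/NC#N)NCCCCCCn1nc(-c2ccccc2)ccc1=O`, 29.1% in this assay

Compound 1 stands highest of the two numbers; the nearest, compound 2, lies lower by a number 39.8 percentage points lower from compound 1 to compound 2 (beyond the scatter). That one measured step swaps the group on the saturated chain carbon five bonds along from the aromatic nitrogen, which is not the change under study here, so it carries only as a rough indication that the chain terminus matters.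

The unmeasured compound 3, `C/N=C(\S)N(C)CCCCn1nc(-c2ccccc2)ccc1=O`, differs from compound 1 by a group of 6 heavy atoms (3 carbon, 2 nitrogen, 1 sulfur; no ring) in place of a group of 6 heavy atoms (3 carbon, 2 nitrogen, 1 sulfur; no ring), on a saturated chain carbon, four bonds along the chain from an aromatic nitrogen. The atoms are the same, joined differently; one hydrogen-bond donor leaves.

Going by the values given here, no measured pair mirrors this rearrangement. Among the compounds with values here, the single step from compound 1 to compound 2 was large and downward, but it involved a different group at a different place. A moderate downward step, a number 13.9 percentage points lower from compound 1 to compound 3 (beyond the scatter), is expected for compound 3, with wide uncertainty. The expected value for compound 3 is 55%, ranging from 30% to 80%.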

Compound 3, a percentage reported as inhibition, in the whole organism at one dose (the size of the read-out at that dose, not a potency): 17.5%
The estimate for compound 3 lay 37.5 percentage points above the measured number; the measured number lies below the stated range.
By their numbers in this assay, from the lowest: compound 3; then compound 2; then compound 1.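

Moving the same atoms at this place, on a saturated chain carbon, four bonds along the chain from an aromatic nitrogen, is enough to give a number 51.4 percentage points lower from compound 1 to compound 3 (beyond the scatter) in this assay as the change. Unlike the earlier step, this one leaves the atom make-up intact, so the number at this position follows how the atoms are joined and not only which atoms are present; the entering group also has fewer hydrogen-bond donors. No measured data on hand bear on what lies behind the drop.

Still open, on these data alone, is whether the methyl on the nitrogen or the altered chain accounts for the loss, as the two change together here. Also open, as far as these compounds go, is how a carbonyl oxygen in place of the sulfur, or a terminal amine, would read in this assay.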